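The source may report more compounds than this note shows. Statements on the series, on what has been measured and on what is new or still open speak of the compounds shown alone.

Compound 2 `O=C(Nc1ccc(O)cc1)C1CCc2ccccc2N1` carries a hydroxy group on the anilide ring of the shared core. In a functional assay on NUGC-3 cells (Homo sapiens) for cytotoxicity, read by sulforhodamine B assay, with a stated time of 72 h (a lower number here means a stronger inhibitor of growth, a higher number a weaker inhibitor of growth), compound 2 gives > 100000 nM, which is a limit of the assay and not a number. Compound 1 `O=C(Nc1ccccc1C(F)(F)F)C1CCc2ccccc2N1`, which bears a trifluoromethyl group on that ring, gives 39300 nM in this assay, and compound 3 `O=C(Nc1ccccc1C(F)(F)F)C1CCc2ccccc2N1C(=O)c1cccc(Cl)c1`, which adds a (3-chlorophenyl)carbonyl group on the ring nitrogen of the core, gives 754 nM. Within the data shown here, only one step between measured compounds is known: a 52-fold lower number from compound 1 to compound 3 (1.72 log units; beyond the scatter). Among the three values, one sits at the limit of > 100000 nM in this assay, at which 1 of the 3 values shown sits, and that is the value of compound 2.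

Compound 4 `O=C(Nc1ccccc1)C1CCc2ccccc2N1` differs from compound 2 by hydrogen in place of hydroxy on an aromatic carbon. Among the measured compounds shown here, no measured step touches that position, so the step from compound 1 to compound 3, which concerns the ring nitrogen, offers no direct guide. What remains is that compound 2 and compound 1 both sit at the weak end of this assay, and compound 4 keeps the same free ring nitrogen as both. Compound 4 is therefore expected to remain weak, with the expected step of an at least 1.4-fold lower number from compound 2 to compound 4 (0.15 log units; that floor lies within the scatter) small and poorly defined because compound 2 gives > 100000 nM as a limit. The estimated value for compound 4 is 70000 nM, with a range from 20000 nM to 200000 nM.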

Compound 4, concentration for 50% growth inhibition: 59000 nM
Estimate against measurement, compound 4: 1.2-fold (0.07 log units) above; low and high end bracket the measured number.
By their numbers in this assay, from the lowest: compound 3; then compounds 1 and 4 (each within the scatter of the next). At a limit, above all of these: compound 2.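

Among these compounds, compound 4 gives the first reading of the shared core with only hydrogen on the anilide ring, and in this assay the exchange of trifluoromethyl for hydrogen stays within the scatter, at a 1.5-fold higher number from compound 1 to compound 4 (0.18 log units; within the scatter). On the hydroxy side, on an aromatic carbon para to a large group, the exchange for hydrogen gives an at least 1.6-fold lower number from compound 2 to compound 4 (0.22 log units; that floor lies within the scatter), so the floor of this step shows no effect of the hydroxy group beyond the scatter and sets no upper bound on its size. The value of compound 2 is a limit and not a number: the limit of > 100000 nM in this assay, at which 1 of the 4 values shown sits.

The compounds shown leave open whether an amine, a carboxylic acid or a longer chain on the anilide ring would move the number beyond the scatter while the ring nitrogen stays free. They also leave open whether the (3-chlorophenyl)carbonyl group on the ring nitrogen would lower the number as far with the anilide ring of compound 4 or of compound 2 as it does with that of compound 1.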